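Removing One Methoxy Group from a Dienone Cyclohexanone Series

A few compounds are considered here, and "the series" means these few. Any claim that something is new, unique, unknown or untested is made for them only; others in the source may bear on it.

Compound 2 `COc1ccc(/C=C2\CCC/C(=C\c3ccc([N+](=O)[O-])cc3)C2=O)cc1OC` is the point of departure. In a functional assay on HSC-2 cells (Homo sapiens) for cytotoxicity (on this read-out higher numbers stand for lower toxicity in this test and lower numbers for higher toxicity in this test), compound 2 gives 2300 nM, the lowest of the two numbers reported here. Compound 3 `COc1cc(/C=C2/C(=O)/C(=C/c3ccc([N+](=O)[O-])cc3)c3ccccc32)cc(OC)c1OC` gives 221000 nM in this assay, a gap to compound 2 that lies well beyond the scatter of the method. Compound 1 `COc1cc(/C=C2\CC/C(=C\c3ccc([N+](=O)[O-])cc3)C2=O)cc(OC)c1OC` sits at the limit of > 400000 nM in this assay, at which 1 of the 3 values shown sits. In this assay compound 1 gives > 400000 nM, which is a limit of the test and not a number.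

Compound 4 `COc1ccc(/C=C2\CCC/C(=C\c3ccc([N+](=O)[O-])cc3)C2=O)cc1` differs from compound 2 by hydrogen in place of methoxy on an aromatic carbon. For the measured compounds named here, no measured pair in this set shares that change, so its size is not known from these data. Compound 4 is expected to give about 5000 nM in this assay, within a range from 1500 nM to 20000 nM. This estimate means a step of a 2.2-fold higher number from compound 2 to compound 4 (0.34 log units; beyond the scatter), expected to be modest, toward a higher number, and possibly no larger than the scatter.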

Compound 4, half-maximal cytotoxic concentration: > 400000 nM
Compound 4 ended at the assay's limit; the forecaster's own chance of this, stated with the estimate: 10%; at least 80-fold (1.90 log units) between middle value and limit.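

Hydrogen in place of methoxy on an aromatic carbon, ortho to a methoxy group, gives the first single-place comparison in this set: in this assay it brings an at least 170-fold higher number from compound 2 to compound 4 (2.24 log units; beyond the scatter). This shows that the methoxy group at this position matters greatly to the cytotoxicity of compound 2 in this test, and that the change is far from a minor edit. Compound 4 sits at a limit of the assay, which is not a number, so the step has a lower bound but no known full size: the limit of > 400000 nM in this assay, at which 2 of the 4 values shown sit.

The compounds shown leave open whether a hydroxyl, an ethoxy group or a fluorine on this carbon would keep the low number of compound 2. They also leave open whether the same change would act alike on the core of compound 3.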